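Fluoro for Trifluoromethyl on the Sulfonyl Aryl Ring

The source may report more compounds than this note shows. Statements on the series, on what has been measured and on what is new or still open speak of the compounds shown alone.

Measured compounds:
compound 1 `O=C1/C(=C/c2cccnc2)CN(S(=O)(=O)c2ccc(Cl)cc2)C/C1=C\c1ccccc1F`: 12400 nM
compound 2 `O=C1/C(=C/c2cccnc2)CN(S(=O)(=O)c2ccc(Cl)cc2)C/C1=C\c1ccccc1C(F)(F)F`: 3620 nM
compound 3 `O=C1/C(=C/c2ccncc2)CN(S(=O)(=O)c2ccc(C(F)(F)F)cc2)C/C1=C\c1ccccc1C(F)(F)F`: 3240 nM

In a functional assay on HepG2 cells (Homo sapiens) for cytotoxicity, read by MTT assay, with a stated time of 24 h (a lower number here means a stronger inhibitor, a higher number a weaker inhibitor), compound 2 gives 3620 nM and compound 1 gives 12400 nM. The step of a 3.4-fold higher number from compound 2 to compound 1 (0.53 log units; beyond the scatter) comes from the change (fluoro in place of trifluoromethyl on an aromatic carbon). Compound 3 and compound 2 differ in more than one place, and the difference between the two cores is not broken down here. Compound 4 `O=C1/C(=C/c2ccncc2)CN(S(=O)(=O)c2ccc(F)cc2)C/C1=C\c1ccccc1C(F)(F)F` differs from compound 3 by fluoro in place of trifluoromethyl on an aromatic carbon. This is the same kind of change as that from compound 2 to compound 1, not the same: there the fluoro sits ortho to a large group, here para to a large group. For compound 4 the expected step is a 2.3-fold higher number from compound 3 to compound 4 (0.36 log units; beyond the scatter), which rests on a 3.4-fold higher number from compound 2 to compound 1 (0.53 log units; beyond the scatter) while allowing for the different place. Compound 4 is expected to give about 7500 nM, estimated between 2800 nM and 20000 nM.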

Compound 4, half-maximal inhibitory concentration: 4010 nM
Compound 4: the middle estimate sits 1.9-fold (0.27 log units) above what was measured; measured number inside the range.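

In this assay, fluoro in place of trifluoromethyl does not carry over with the same size from one core to the other: the same change on two cores in this assay, a 3.4-fold higher number (0.53 log units; beyond the scatter) from compound 2 to compound 1 and a 1.2-fold higher number (0.09 log units; within the scatter) from compound 3 to compound 4, 2.8-fold (0.44 log units) apart, beyond the scatter of two such steps. On the newer core the step is a 1.2-fold higher number from compound 3 to compound 4 (0.09 log units; within the scatter), so the change that separated the earlier pair does not separate this one. The two steps differ both in where the change sits and in the rest of the core, and two pairs cannot show which of these accounts for the gap or give a rule for the series.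

The compounds shown leave open how an amine or a carboxylic acid would read in that same place, para to a large group. They also leave open how the change would behave on any further core.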